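The source may report more compounds than this note shows. Statements on the series, on what has been measured and on what is new or still open speak of the compounds shown alone.

Of the compounds shown here, three have been tested in a functional assay on EL4 cells (Mus musculus) for inhibition, tested at 100 uM; on this read-out higher numbers stand for more inhibition at the one concentration tested (going by the name of the read-out) and lower numbers for less inhibition. Compound 1, `OC[C@H]1O[C@@H](n2cnc3c(NCc4ccccc4)nccc32)C[C@@H]1O`, gives 8% in this assay. Compound 2, `CNc1[nH]ccc2ncnc1-2`, gives only < 5% in this assay, which is a limit of the assay rather than a number. Compound 3, `OC[C@H]1OC(n2cnc3c(S)nccc32)[C@H](O)[C@@H]1O`, gives < 5% in this assay, again a limit and not a number. Compound 2 thus stands at the limit of < 5% in this assay, at which 2 of the 3 values shown sit, with no measured number of its own from which a comparison could start. Compound 4, `OCCNc1[nH]ccc2ncnc1-2`, has not yet been measured; it differs from compound 2 by hydroxymethyl in place of hydrogen on a saturated chain carbon bound to a nitrogen on an aromatic ring. For the measured compounds named here, no two measured compounds differ in a single place, so no measured step shows what such a change does here. With only a limit for compound 2 as the starting point, the change from compound 2 to compound 4 is expected to move the reading in this assay by no more than the usual scatter, if at all. Compound 4 is therefore estimated at 5% in this assay, within a range from 0% to 15%. The step itself is expected to read a number no lower from compound 2 to compound 4 (the limit leaves the size open), within the usual scatter.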

Compound 4, a percentage reported as inhibition, at one concentration (the size of the read-out at that concentration, not a potency): < 5%
Compound 4 was reported as a limit; the forecaster's own chance of this, stated with the estimate: 60%; the middle value sits exactly at the limit.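

Compound 2 and compound 4 both stand only as limits rather than numbers, so no step can be read from one to the other: the limit of < 5% in this assay, at which 3 of the 4 values shown sit.

On these data alone, whether hydroxymethyl in place of hydrogen on a saturated chain carbon changes the reading at all remains open.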